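A few compounds are considered here, and "the series" means these few. Any claim that something is new, unique, unknown or untested is made for them only; others in the source may bear on it.

Compound 1 `C=CCSc1nncc2cnc(C)n12` is one of three close analogues measured in a functional assay for inhibition, with Homo sapiens as the target; on this read-out lower numbers stand for stronger inhibition and higher numbers for weaker inhibition. In this assay compound 1 gives 61000 nM, the lowest of the two numbers read out. Compound 3 `C=CCSc1nncc2cnc(COC)n12`, which carries methoxy in place of hydrogen on the saturated chain carbon bound to an aromatic carbon, gives 79000 nM in this assay; the step of a 1.3-fold higher number from compound 1 to compound 3 (0.11 log units; within the scatter) lies within the scatter. Compound 2 `C=CCSc1nncc2cnc(-c3ccccc3)n12` bears phenyl in place of methyl on an aromatic carbon. For compound 2 this assay reports only a limit, > 48000 nM. Since one of the three values sits at this limit (the limit of > 48000 nM in this assay, at which 1 of the 3 values shown sits), the steps a step that the limit leaves unreadable from compound 1 to compound 2 and a step that the limit leaves unreadable from compound 2 to compound 3 cannot be read in size.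

Compound 4 `CSc1nncc2cnc(C)n12` is not yet measured. It differs from compound 1 by hydrogen in place of vinyl on a saturated chain carbon bound to a sulfur. Among the measured compounds shown here, none of the measured steps touches the sulfur-bound chain; all three concern the substituent on the aromatic carbon, and the one readable step, a 1.3-fold higher number from compound 1 to compound 3 (0.11 log units; within the scatter), stayed within the scatter. Nothing measured therefore points to a step beyond the scatter, in either direction, for compound 4 in this assay. Compound 4 is expected to give 75000 nM in this assay, with a range from 30000 nM to 200000 nM. This estimate means a step of a 1.2-fold higher number from compound 1 to compound 4 (0.09 log units; within the scatter) that is expected to lie within the scatter.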

Compound 4, half-maximal inhibitory concentration: > 48000 nM
Compound 4 was reported as a limit (the forecaster's own chance of this, stated with the estimate: 35%); the middle value lies beyond the limit too.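

For compound 4, this assay gives > 48000 nM as a limit and not as a number. The step from compound 1 to compound 4 therefore cannot be read in size, and no new step follows from this result: the limit of > 48000 nM in this assay, at which 2 of the 4 values shown sit.

The compounds shown leave open whether allylsulfanyl and methylsulfanyl differ at all on this read-out.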